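The source may hold more compounds than are shown below. What is called first, only, known or untested is meant among the compounds shown, and "the series" means these compounds.

Measured compounds:
compound 1 `CNC(=O)c1cc(Oc2ccc(NC(=O)c3nn(-c4ccccc4C(F)(F)F)c(=O)cc3C)cc2F)ccn1` — > 40000 nM
compound 2 `CNC(=O)c1cc(Oc2ccc(NC(=O)c3nn(-c4ccc(Br)cc4F)c(=O)cc3C)cc2F)ccn1` — 2830 nM
compound 3 `Cc1cc(=O)n(-c2ccccc2C(F)(F)F)nc1C(=O)Nc1ccc(Oc2ncnc3ccsc23)cc1` — 9230 nM

All three were tested in a functional assay on HepG2 cells (Homo sapiens) for cytotoxicity, read by MTT assay, with a stated time of 72 h (on this read-out higher numbers stand for weaker inhibition and lower numbers for stronger inhibition), a measure of how strongly a compound harms liver-derived cancer cells. For compound 1 the value is a limit of the assay, not a number: the limit of > 40000 nM in this assay, at which 1 of the 3 values shown sits. Compound 2 carries a 4-bromo-2-fluorophenyl in place of the 2-(trifluoromethyl)phenyl of compound 1 (4-bromo-2-fluorophenyl in place of 2-(trifluoromethyl)phenyl on an aromatic nitrogen), and this change brought an at least 14-fold lower number from compound 1 to compound 2 (1.15 log units; beyond the scatter). Compound 3 has a different core; the difference between the two cores is not broken down here. In this assay compound 3 gives 9230 nM, the highest of the two numbers recorded.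

Compound 4 `Cc1cc(=O)n(-c2ccc(Br)cc2F)nc1C(=O)Nc1ccc(Oc2ncnc3ccsc23)cc1` is not yet measured. It differs from compound 3 by the same kind of change (4-bromo-2-fluorophenyl in place of 2-(trifluoromethyl)phenyl on an aromatic nitrogen). Resting on the large drop seen in an at least 14-fold lower number from compound 1 to compound 2 (1.15 log units; beyond the scatter), a step of similar direction is expected, a 4.6-fold lower number from compound 3 to compound 4 (0.66 log units; beyond the scatter), starting from the measured number of compound 3 9230 nM. Compound 4 is therefore estimated at 2000 nM, within 500 nM to 7000 nM.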

Compound 4, half-maximal inhibitory concentration: 10600 nM
Beside the measured number, compound 4's estimate is 5.3-fold (0.72 log units) below it, and the stated range ends below it.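

In this assay, putting 4-bromo-2-fluorophenyl in place of 2-(trifluoromethyl)phenyl on the core of compound 3 gives a 1.1-fold higher number from compound 3 to compound 4 (0.06 log units; within the scatter), so on this core the change has no effect that can be told from the scatter. The same change therefore did not carry over from one core to the other with the same size: the same change on two cores in this assay, an at least 14-fold lower number (1.15 log units; beyond the scatter) from compound 1 to compound 2 and a 1.1-fold higher number (0.06 log units; within the scatter) from compound 3 to compound 4, at least 16-fold (1.21 log units) apart, beyond the scatter of two such steps. Only two cores are shown, so this warns against transferring the step but does not show why the two steps part or how the change would behave on a further core.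

As far as these compounds go, it remains open how a plain phenyl or an ethyl chain on the same aromatic nitrogen would behave on either core. Also open, from the compounds shown here alone, is which part of the two cores decides the size of the step.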